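A few compounds are considered here, and "the series" means these few. Any claim that something is new, unique, unknown or untested is made for them only; others in the source may bear on it.

Measured so far:
compound 1 `Cc1cc(NCc2c[nH]cn2)n2nc(C)c(-c3ccccc3)c2n1` — 14600 nM
compound 2 `Cc1cc(NCc2cccs2)n2nc(C)c(-c3ccccc3)c2n1` — < 5000 nM
compound 3 `Cc1cc(NCc2ccccn2)n2ncc(-c3ccc(N(C)C)cc3)c2n1` — < 5000 nM

Within the data shown here, in a physicochemical assay for solubility, read by HPLC, using the shake flask method, measured as kinetic solubility, with a stated time of 2 h, at pH 7.4 (a lower number here means a less soluble compound, a higher number a more soluble compound), compound 1 gives 14600 nM, the only plain number in the set. Compound 2 gives < 5000 nM, which is a limit of the assay. Compound 3 likewise gives < 5000 nM, a limit and not a number. Among the measured compounds shown here, the single step between measured compounds is an at least 2.9-fold lower number from compound 1 to compound 2 (0.46 log units; beyond the scatter), and it runs into the limit rather than to a number. Taken together, the limit of < 5000 nM in this assay, at which 2 of the 3 values shown sit, means that compound 3 stands at the floor of what this assay can report, with no measured neighbour resolved below it.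

Compound 4 `Cc1cc(NCc2ccccn2)n2ncc(-c3ccco3)c2n1` is not yet measured. It differs from compound 3 in one place: furan-2-yl in place of 4-(dimethylamino)phenyl on an aromatic carbon. For the measured compounds named here, no measured step concerns this position; the step from compound 1 to compound 2 changes the group on the saturated chain carbon bound to a nitrogen on an aromatic ring, not the group on the fused five-membered ring. With compound 3 at a limit, the size of the step from compound 3 to compound 4 in this assay cannot be read from a measured pair. The expected step is an at least 1.2-fold higher number from compound 3 to compound 4 (0.07 log units; that floor lies within the scatter), an expectation only. Compound 4 is estimated at 6000 nM, with a range of 2000 nM to 20000 nM.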

Compound 4, solubility: 48800 nM
Compound 4: the middle estimate sits 8.1-fold (0.91 log units) below what was measured, and the stated range ends below it.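

The group on this aromatic carbon of the five-membered aromatic ring with 2 nitrogen can move the read-out in this assay, with furan-2-yl in place of 4-(dimethylamino)phenyl giving an at least 9.7-fold higher number from compound 3 to compound 4 (0.98 log units; beyond the scatter). The earlier compounds shown here offered one readable step, at a different place, on the saturated chain carbon bound to a nitrogen on an aromatic ring: an at least 2.9-fold lower number from compound 1 to compound 2 (0.46 log units; beyond the scatter). That step went downward, whereas this change gives the series its first upward step, and it lies beyond the scatter even as a minimum, although compound 3 gives < 5000 nM, which is a limit and not a number, so the full size of the step stays unread: the limit of < 5000 nM in this assay, at which 2 of the 4 values shown sit.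

The change swaps a six-membered aromatic ring of carbon only for a five-membered aromatic ring with 1 hetero atom and also removes the dimethylamino group, so the compounds shown do not tell which of these carries the step. Also open, as far as these compounds go, is how a morpholine or a carboxylic acid on this aromatic carbon would read, and whether the step holds with the other chain groups and the extra methyl groups of compound 1 and compound 2.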